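A few compounds are considered here, and "the series" means these few. Any claim that something is new, unique, unknown or untested is made for them only; others in the source may bear on it.

Working notes on the series. Compound 1 `COc1cc(-c2nn(-c3cccc(NC(=O)Nc4ccc(Cl)c(Cl)c4)c3)cc2-c2ccncc2)ccc1Cl` gives 2800 nM in a functional assay on SR cells (Homo sapiens) for inhibition, read by sulforhodamine B assay, with a stated time of 48 h; on this read-out higher numbers stand for weaker inhibition of growth and lower numbers for stronger inhibition of growth. Compound 2 `COc1cc(-c2nn(-c3cccc(NC(=O)Nc4cccc(C(F)(F)F)c4)c3)cc2-c2ccncc2)ccc1Cl` gives 2840 nM in this assay; between them, a 1.0-fold higher number from compound 1 to compound 2 (0.01 log units; within the scatter). Compound 3 `COc1cc(-c2nn(-c3cccc(NC(=O)c4ccc(Cl)c(C(F)(F)F)c4)c3)cc2-c2ccncc2)ccc1Cl` returns only a limit in this assay, namely > 32500 nM. On the numbers shown, compound 3 therefore stands at the upper edge of what is reported (the limit of > 32500 nM in this assay, at which 1 of the 3 values shown sits), and the steps onto it can be given only as bounds: an at least 11-fold higher number from compound 1 to compound 3 (1.06 log units; beyond the scatter) and an at least 11-fold higher number from compound 2 to compound 3 (1.05 log units; beyond the scatter).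

Compound 4 `COc1cc(-c2nn(-c3cccc(NC(=O)Nc4ccc(Cl)c(C(F)(F)F)c4)c3)cc2-c2ccncc2)ccc1Cl` differs from compound 3 by (4-chloro-3-(trifluoromethyl)phenyl)amino in place of 4-chloro-3-(trifluoromethyl)phenyl on a carbonyl carbon, which restores the amino link on the carbonyl carbon that compound 1 and compound 2 carry. Both measured steps that bear on this change run the opposite way, from amino-linked carbonyl to directly attached aryl, and both were large, so for compound 4 a large fall in number in this assay is expected, back toward where compound 1 and compound 2 sit. The estimate for compound 4 is 2800 nM in this assay, with a range of 1000 nM to 9000 nM. The expected step is an at least 11-fold lower number from compound 3 to compound 4 (1.06 log units; beyond the scatter).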

Compound 4, concentration for total growth inhibition: 2480 nM
Compound 4: the middle estimate sits 1.1-fold (0.05 log units) above what was measured, within the range that was stated.
By their numbers in this assay, from the lowest: compounds 4, 1 and 2 (each within the scatter of the next). At a limit, above all of these: compound 3.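

Within the data shown here, with the 4-chloro-3-(trifluoromethyl)phenyl group the same on both sides, the amino link on the carbonyl carbon is read alone for the first time in this assay, and it gives an at least 13-fold lower number from compound 3 to compound 4 (1.11 log units; beyond the scatter). That step is a bound only, since compound 3 stands at a limit and not at a number: the limit of > 32500 nM in this assay, at which 1 of the 4 values shown sits. Among the amino-linked compounds, the aryl substituents leave the read-out within the scatter, with a 1.1-fold lower number from compound 2 to compound 4 (0.06 log units; within the scatter) and a 1.1-fold lower number from compound 1 to compound 4 (0.05 log units; within the scatter).

Still open, going by these compounds, is whether the amide hydrogen of the amino link matters or only the link itself, which a methyl on that nitrogen or a methylene in its place would separate. Also open, on these data alone, is how this aryl group responds to a carboxylic acid or an amine on its ring.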